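Lengthening the Amine Linker: From Compound 3 to Compound 4

The source may hold more compounds than are shown below. What is called first, only, known or untested is meant among the compounds shown, and "the series" means these compounds.

Of the compounds shown here, three built on one shared core have been measured. Compound 1 `O=c1cc(-c2ccccc2)oc2cccc(OCCCCN3CCC(O)CC3)c12` carries a short chain from the aromatic oxygen to a hydroxypiperidine, and in an assay on isolated protein (Cavia porcellus) with Sigma non-opioid intracellular receptor 1 (Homo sapiens) as the target, read by radioligand binding (a higher number here means a weaker inhibitor, a lower number a stronger inhibitor), compound 1 gives 58 nM. Compound 2 `O=c1cc(-c2ccccc2)oc2cccc(OCCCCCCCN3CCC(O)CC3)c12` carries the same ending on a longer chain, and in this assay compound 2 gives 36 nM. The step between them, a 1.6-fold lower number from compound 1 to compound 2 (0.21 log units; within the scatter), shows that lengthening this chain changed little. Compound 3 `CN(C)CCCCOc1ccc2oc(-c3ccccc3)cc(=O)c2c1`, with a dimethylamino ending on the short chain attached at a different position of the core, gives 720 nM in this assay, the highest of the three numbers and well apart from both others.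

Compound 4 `CN(C)CCCCCCCOc1ccc2oc(-c3ccccc3)cc(=O)c2c1`, not yet measured, differs from compound 3 by a single change: 3-(dimethylamino)propyl in place of dimethylamino on a saturated chain carbon, four bonds along the chain from an oxygen on an aromatic ring. This is the same lengthening of the chain seen between compound 1 and compound 2, where the step stayed within the scatter. A similarly small step is therefore expected here, if anything toward a lower number. Compound 4 is estimated to give 500 nM, within a range of 150 nM to 1600 nM. This corresponds to an expected 1.4-fold lower number from compound 3 to compound 4 (0.16 log units; within the scatter).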

Compound 4, half-maximal inhibitory concentration: 165 nM
Beside the measured number, compound 4's estimate is 3.0-fold (0.48 log units) above it; measured number inside the range.
By their numbers in this assay, from the lowest: compounds 2 and 1 (each within the scatter of the next); then compound 4; then compound 3.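

In this assay the same lengthening of the chain gives a 4.4-fold lower number from compound 3 to compound 4 (0.64 log units; beyond the scatter) with the dimethylamino ending, whereas the 4-hydroxypiperidin-1-yl ending gave a 1.6-fold lower number from compound 1 to compound 2 (0.21 log units; within the scatter) on the other pair. This change at this saturated chain carbon can therefore move the number beyond the scatter, and its size does not simply carry over from one pair to the other. Nothing available explains why the longer chain lowers the number here.

As far as these compounds go, compound 3 and compound 4 differ from the earlier pair in both the amine ending and the place where the chain meets the core, so it remains open which of these goes with the larger step. Also open, from the compounds shown here alone, is how a still longer chain, or another amine such as morpholine or pyrrolidine, would read at this position.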